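A Five-Membered Ring Swap on the Sulfur Bridge

A few compounds are considered here, and "the series" means these few. Any claim that something is new, unique, unknown or untested is made for them only; others in the source may bear on it.

In an assay on isolated protein for inhibition of RAC-alpha serine/threonine-protein kinase (Homo sapiens), read by fluorescence, with a stated time of 30 min, tested at 10 uM (a higher number here means more inhibition at the concentration tested (going by the name of the read-out), a lower number less inhibition), compound 1 `O=C(Nc1cc(Sc2ncnc3nc[nH]c23)c(O)c2ccccc12)c1ccc(Cl)cc1` gives 21.7%. Compound 3 `COc1cccc(C(=O)Nc2cc(Sc3ncn[nH]3)c(O)c3ccccc23)c1` gives 19.4% in this assay. Compound 2 `O=C(Nc1cc(Sc2nncs2)c(O)c2ccccc12)c1ccc(Cl)cc1` gives 7.5%, the lowest of the three numbers: compound 3 lies above it beyond the scatter, and compound 1 further above, also beyond the scatter. Among the measured compounds shown here, the only measured step that changes the ring on the sulfur is the one from compound 1 to compound 2, a number 14.2 percentage points lower from compound 1 to compound 2 (beyond the scatter), in which a five-membered ring with 3 hetero atoms took the place of a fused pair of rings. Compound 4 `Cn1nnnc1Sc1cc(NC(=O)c2ccc(Cl)cc2)c2ccccc2c1O` is not yet measured and differs from compound 2 in one place: 1-methyl-1H-tetrazol-5-yl in place of 1,3,4-thiadiazol-2-yl on a sulfur. For the measured compounds named here, both rings in this change are five-membered aromatic rings, so the structural change is far smaller than the one from compound 1 to compound 2, and the expected step from compound 2 to compound 4 is a number 2.5 percentage points higher from compound 2 to compound 4 (within the scatter), within the scatter. Compound 4 is therefore estimated to give about 10% in this assay, somewhere between 0% and 25%.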

Compound 4, a percentage reported as inhibition, at one concentration (the size of the read-out at that concentration, not a potency): 13.1%
Estimate against measurement, compound 4: 3.1 percentage points below; the measured number falls inside the stated range.
By their numbers in this assay, from the lowest: compounds 2, 4, 3 and 1 (each within the scatter of the next, the first and the last beyond it).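

With 1-methyl-1H-tetrazol-5-yl in place of 1,3,4-thiadiazol-2-yl on the sulfur, this assay gives a number 5.6 percentage points higher from compound 2 to compound 4 (within the scatter), so these two five-membered rings cannot be told apart at this position. The fused pair of rings of compound 1 gave way to the thiadiazolyl ring with a step beyond the scatter, but the parallel exchange for the tetrazolyl ring gives a number 8.6 percentage points lower from compound 1 to compound 4 (within the scatter), so the loss seen earlier does not hold for every five-membered ring placed here. Nothing shown accounts for either step.

The compounds shown leave open how an open chain on the sulfur, such as a longer alkyl chain ending in an amine or a carboxylic acid, would compare with these rings. They also leave open whether a five-membered ring carrying an amine would read differently from the methyl-bearing tetrazolyl ring.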